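The source may report more compounds than this note shows. Statements on the series, on what has been measured and on what is new or still open speak of the compounds shown alone.

Measured in a functional assay on HeLa cells (Homo sapiens) for antiproliferative activity, read by CCK-8 assay, with a stated time of 72 h; on this read-out higher numbers stand for weaker inhibition and lower numbers for stronger inhibition:
Compound 1 `COc1ccc(-c2cncnc2-c2cc(OC)c(OC)c(OC)c2)cc1O`: 280 nM
Compound 2 `COc1cc(-c2ncncc2-c2ccc(OC(C)C)cc2)cc(OC)c1OC`: 8360 nM
Compound 3 `COc1ccc(-c2cncnc2-c2cc(OC)c(OC)c(OC)c2)nc1`: 470 nM

Compound 3, at 470 nM, cannot be told apart from compound 1 on these numbers, while compound 2, at 8360 nM, lies beyond the scatter from compound 3, on the side of weaker inhibition.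

The next structure is compound 4 `COc1cc(-c2ncncc2-c2ccc(B(O)O)cc2)cc(OC)c1OC`, and the change to it is a group of 9 heavy atoms (6 carbon, 1 boron, 2 oxygen; one six-membered aromatic ring of carbon only) in place of a group of 8 heavy atoms (6 carbon, 1 nitrogen, 1 oxygen; one six-membered aromatic ring with 1 hetero atom), on an aromatic carbon. It removes 5-methoxypyridin-2-yl and brings in a group with no common name, on an aromatic carbon, ortho to a large group.

Going by the values given here, only one measured step bears directly on this place: a 1.7-fold higher number from compound 1 to compound 3 (0.22 log units; within the scatter). That swap left this assay within the scatter. Among the compounds with values here, still, it is a single step, and no measured compound contains boron. Compound 2, at 8360 nM, also shows that a much higher number is possible among these compounds, so the expectation leans upward and the range stays wide.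

The expected step is a 1.7-fold higher number from compound 3 to compound 4 (0.23 log units; within the scatter), which is not expected to clearly exceed the scatter. For compound 4 the estimated value is 800 nM, with an expected range from 150 nM to 5000 nM.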

Compound 4, half-maximal inhibitory concentration: 4000 nM
Compound 4: middle estimate off by 5.0-fold (0.70 log units), on the low side, within the range that was stated.
By their numbers in this assay, from the lowest: compounds 1 and 3 (each within the scatter of the next); then compound 4; then compound 2.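

Where the earlier swap at this place stayed within the scatter, the boron-carrying group moves the read-out in this assay clearly, with an 8.5-fold higher number from compound 3 to compound 4 (0.93 log units; beyond the scatter), so this place does not treat every six-membered aromatic group alike. The loss is larger against the 3-hydroxy-4-methoxyphenyl group, with a 14-fold higher number from compound 1 to compound 4 (1.15 log units; beyond the scatter), whereas exchanging the isopropoxy group of compound 2 for the boron-bearing group on the same ring gives only a 2.1-fold lower number from compound 2 to compound 4 (0.32 log units; beyond the scatter), which leaves compound 4 much closer to compound 2 than to compound 1 or compound 3. No evidence is available here to account for these differences.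

The compounds shown leave open whether a carboxylic acid or an amine on that same ring, in place of the boron-bearing group, would fall nearer compound 1 or nearer compound 2. They also leave open how an unsubstituted phenyl or a 4-methoxyphenyl group at this place would compare, and so how much of the number for compound 1 depends on its hydroxy group.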